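A hydroxy group in place of chloro on a thiazolidinone scaffold

The source may hold more compounds than are shown below. What is called first, only, known or untested is meant among the compounds shown, and "the series" means these compounds.

Two compounds that share one core have been examined in an ADME assay on Vero cells (Chlorocebus sabaeus) for cytotoxicity, read by neutral red uptake, tested at 3150 ug/mL; a lower number here means a stronger effect, a higher number a weaker effect of the compound at the concentration tested. Compound 1 `COc1ccc(C2SCC(=O)N2CCN2CCCCC2)cc1` gives 11% in this assay. Compound 2 `O=C1CSC(c2cccc(Cl)c2)N1CCN1CCCCC1` gives 15% in this assay. Compound 2 therefore stands alongside compound 1, the two numbers lying within the usual scatter of each other, so nothing can be said about which of them acts more strongly at the concentration tested.

Compound 3 `O=C1CSC(c2cccc(O)c2)N1CCN1CCCCC1` has not yet been measured in this assay. It differs from compound 2 in one place: hydroxy in place of chloro on an aromatic carbon. Going by the values given here, no step between two measured compounds is available to show how such a change plays out in this assay, so the expectation rests only on the two numbers given. Both of them are small, and the account expects the step of a number 2 percentage points lower from compound 2 to compound 3 (within the scatter) to stay within the scatter, in no clear direction. For compound 3 the estimated value in this assay is 13%, with a range from 3% to 28%.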

Compound 3, a percentage reported as activity, at one concentration (the size of the read-out at that concentration, not a potency): 11%
Estimate against measurement, compound 3: 2 percentage points above; the measured number falls inside the stated range.
By their numbers in this assay, from the lowest: compounds 1, 3 and 2 (each within the scatter of the next).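

Hydroxy in place of chloro on this aromatic carbon, meta to a large group, gives the first step between measured compounds that differ in one place, and in this assay it reads a number 4 percentage points lower from compound 2 to compound 3 (within the scatter) for the change from 3-chlorophenyl to 3-hydroxyphenyl. At this position, then, a chlorine atom can give way to an oxygen atom, with one hydrogen-bond donor and one hydrogen-bond acceptor entering, and the read-out at the concentration tested shows no difference that can be told from the scatter, though this rests on a single pair. No measurement at hand bears on what lies behind this result.

The compounds shown leave open whether this position stays as unresponsive in this assay with a different kind of group on the same carbon, such as an amine, a carboxylic acid or a longer chain such as an ethyl or propyl group. They also leave open whether hydroxy in place of chloro would give a similar step on another carbon of the ring or on a different group attached to the shared core.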